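The compounds below may be only part of what the source reports. "The series", "measured", "known", "first", "only" and "open" are said of these compounds alone.

Values in a physicochemical assay for solubility, in phosphate buffer, at pH 7.4 (a higher number here means a more soluble compound, a lower number a less soluble compound), so far:
- compound 1 `CCOC(=O)c1c(-c2cccc(F)c2)[nH]c2cc(OC)ccc2c1=O`: > 100000 nM (a limit, not a number)
- compound 2 `CCOC(=O)c1c(-c2cccc([N+](=O)[O-])c2)[nH]c2cc(OC)ccc2c1=O`: 13000 nM

For the measured compounds named here, compound 2 holds the only actual number. Next is compound 3 `CCOC(=O)c1c(-c2ccc(Cl)c(Cl)c2)[nH]c2cc(OC)ccc2c1=O`, where 3,4-dichlorophenyl stands in place of 3-nitrophenyl on an aromatic carbon next to the ring nitrogen (3,4-dichlorophenyl in place of 3-nitrophenyl on an aromatic carbon). Going by the values given here, one measured step bears on this, a change on the same phenyl group: an at least 7.6-fold lower number from compound 1 to compound 2 (0.88 log units; beyond the scatter). Its size is open-ended because of the limit of > 100000 nM in this assay, at which 1 of the 2 values shown sits. That step shows that such changes can move this assay beyond the scatter, but it does not fix the direction for this replacement. A modest move to a lower number is expected, with low confidence. The expected step is a 2.6-fold lower number from compound 2 to compound 3 (0.41 log units; beyond the scatter). For compound 3 the estimate is 5000 nM, with an expected range of 1000 nM to 25000 nM.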

Compound 3, solubility: 17000 nM
Beside the measured number, compound 3's estimate is 3.4-fold (0.53 log units) below it; low and high end bracket the measured number.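

In this assay, a new kind of substitution on the phenyl group at this position, 3,4-dichlorophenyl in place of 3-nitrophenyl, gives a 1.3-fold higher number from compound 2 to compound 3 (0.12 log units; within the scatter), so this change leaves the read-out unresolved between the two compounds. Against 3-fluorophenyl, the same group gives an at least 5.8-fold lower number from compound 1 to compound 3 (0.76 log units; beyond the scatter), which makes compound 3 the second compound, after compound 2, to lie beyond the scatter from compound 1. The size of both steps from compound 1 stays open-ended because that compound stands at a limit: the limit of > 100000 nM in this assay, at which 1 of the 3 values shown sits.

The compounds shown do not tell whether 3-fluorophenyl alone stands apart or how a phenyl group carrying an amine or a carboxylic acid would read at this position. They also leave open whether these steps hold when the ethoxycarbonyl group gives way to a carboxylic acid.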